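The source may hold more compounds than are shown below. What is called first, only, known or untested is meant among the compounds shown, and "the series" means these compounds.

Compound 1 `CCCOC(=O)Nc1ccc([Se]C#N)cc1` is a propyl carbamate carrying a selenocyanate group. Among the measured compounds shown here, in an ADME assay on BEAS-2B cells (Homo sapiens) for cytotoxicity, read by MTT assay, with a stated time of 72 h (on this read-out lower numbers stand for stronger inhibition of growth and higher numbers for weaker inhibition of growth), compound 1 gives 19200 nM, the highest of the two numbers known here. Compound 2 `Cc1ccc(OC(=O)Nc2ccc([Se][Se]c3ccc(NC(=O)Oc4ccc(C)cc4)cc3)cc2)cc1`, a diselenide built from two aryl carbamates, gives 700 nM in this assay, a gap beyond the scatter, but compound 2 differs from compound 1 in more than one way. As far as these compounds go, compound 3 `N#C[Se]c1ccc(NC(=O)Oc2ccccc2)cc1` is untested. It differs from compound 1 by phenyl in place of propyl on an oxygen next to a carbonyl group. The step of a 2.1-fold lower number from compound 1 to compound 3 (0.33 log units; beyond the scatter) is expected to be small, toward a lower number. Compound 3 is estimated at 9000 nM, between 3000 nM and 27000 nM.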

Compound 3, concentration for 50% growth inhibition: 8900 nM
Estimate against measurement, compound 3: 1.0-fold (0.00 log units) above; low and high end bracket the measured number.
By their numbers in this assay, from the lowest: compound 2; then compound 3; then compound 1.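

On an oxygen next to a carbonyl group, phenyl in place of propyl gives a 2.2-fold lower number from compound 1 to compound 3 (0.33 log units; beyond the scatter) in this assay. So a six-membered aromatic ring of carbon only can replace the small chain here, and growth inhibition grows stronger by a modest step. Nothing measured here accounts for that step. As far as these compounds go, whether a longer chain, or a phenyl carrying an amine or a carboxylic acid, would move the number further stays open. Compound 2 differs from compound 3 in more than one place, so the selenocyanate and diselenide forms cannot be compared directly.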